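This account rests on a few compounds, and the source may have more. Where it says the series, first, only, none or still open, it means among the compounds named here.

Compound 1 `C/C=C(\C)[C@H]1OC(=O)[C@@H](C)NC(=O)[C@H]([C@@H](C)CC)NC(=O)CN(C)C(=O)[C@@H](Cc2ccccc2)N(C)C(=O)[C@H](C)NC(=O)[C@@H](CC(C)C)OC(=O)/C(C)=C/C[C@H](O)[C@@H]1C` is the reference point here. In a functional assay on A549 cells (Homo sapiens) for cytotoxicity, read by CellTiter-Blue, with a stated time of 72 h (on this read-out higher numbers stand for weaker inhibition and lower numbers for stronger inhibition), compound 1 gives 0.0021 nM, the second highest of three numbers. Compound 2 `C/C=C(\C)[C@H]1OC(=O)[C@@H](C)NC(=O)[C@H]([C@@H](C)CC)NC(=O)CN(C)C(=O)[C@@H](Cc2ccccc2)N(C)C(=O)[C@H](C)NC(=O)[C@@H](CC(C)C)OC(=O)/C(C)=C/C[C@H](OCSC)[C@@H]1C` gives 0.00019 nM, a step of an 11-fold lower number from compound 1 to compound 2 (1.04 log units; beyond the scatter) brought by (methylsulfanyl)methyl in place of hydrogen on an oxygen on a saturated carbon. Compound 3 `C/C=C(\C)[C@H]1OC(=O)[C@@H](C)NC(=O)[C@H]([C@@H](C)CC)NC(=O)CN(C)C(=O)[C@@H](Cc2ccccc2)N(C)C(=O)[C@@H](C)NC(=O)[C@@H](CC(C)C)OC(=O)/C(C)=C/C[C@H](O)[C@@H]1C` gives 1050 nM, a step of a 500000-fold higher number from compound 1 to compound 3 (5.70 log units; beyond the scatter) that comes with the fact that compounds 1 and 3 differ only in the configuration as drawn. Compound 4 `C/C=C(\C)[C@H]1OC(=O)[C@@H](C)NC(=O)[C@H]([C@@H](C)CC)NC(=O)CN(C)C(=O)[C@@H](Cc2ccc(Cl)cc2)N(C)C(=O)[C@H](C)NC(=O)[C@@H](CC(C)C)OC(=O)/C(C)=C/C[C@H](O)[C@@H]1C` differs from compound 1 by chloro in place of hydrogen on an aromatic carbon. Neither measured step touches that aromatic ring, so no step beyond the scatter is expected in this assay, in either direction. Compound 4 is therefore estimated at 0.002 nM, within a range of 0.0005 nM to 0.008 nM. The expected step is a 1.1-fold lower number from compound 1 to compound 4 (0.02 log units; within the scatter).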

Compound 4, half-maximal inhibitory concentration: 0.00001 nM
The estimate for compound 4 lay 200-fold (2.30 log units) above the measured number; measured number outside the range, below it.
By their numbers in this assay, from the lowest: compound 4; then compound 2; then compound 1; then compound 3.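

Going by these compounds alone, the ring of the benzyl group, which no earlier step touched, proves highly sensitive: in this assay, a single chlorine gives a 210-fold lower number from compound 1 to compound 4 (2.32 log units; beyond the scatter). That change moves the number further than (methylsulfanyl)methyl on the oxygen does, at an 11-fold lower number from compound 1 to compound 2 (1.04 log units; beyond the scatter). Nothing shown here accounts for the effect of the chlorine.

As far as these compounds go, whether bromo, methyl or an amine in the same place would act like chloro remains open. So does whether chloro and (methylsulfanyl)methyl would add up in a single compound.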